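A Second Methyl on the Amide-Bearing Ring

The source may report more compounds than this note shows. Statements on the series, on what has been measured and on what is new or still open speak of the compounds shown alone.

Compound 1 `CCNC(=O)c1ccc(-c2cc3nnn(C4CCN(c5ncc(CC)cn5)CC4)c3cn2)c(C)c1` and compound 2 `CCNC(=O)c1ccc(-c2cc3nnn(C4CCN(c5ncc(CC)cn5)CC4)c3cn2)cc1C` have the same atoms joined differently; the difference between the two cores is not broken down here. In a functional assay on HEK293 cells for agonist activity at Glucose-dependent insulinotropic receptor (Homo sapiens), read by HTRF and cAMP accumulation, with a stated time of 30 min (a lower number here means that less compound is needed, a higher number that more compound is needed for the effect), compound 1 gives 19 nM and compound 2 gives 18 nM. In this assay compound 3 `CCNC(=O)c1cc(C)c(-c2cc3nnn(C4CCN(c5ncc(CC)cn5)CC4)c3cn2)c(C)c1` gives 83 nM. Compound 3 differs from compound 1 by methyl in place of hydrogen on an aromatic carbon, and the step is a 4.4-fold higher number from compound 1 to compound 3 (0.64 log units; beyond the scatter). Compound 4 `CCNC(=O)c1c(C)cc(-c2cc3nnn(C4CCN(c5ncc(CC)cn5)CC4)c3cn2)cc1C`, not yet measured, differs from compound 2 by methyl in place of hydrogen on an aromatic carbon. This is the same kind of change, not the same one: in compound 3 the methyl sits ortho to a large group and meta to the ethylcarbamoyl group, while in compound 4 it sits ortho to the ethylcarbamoyl group and meta to a large group. Going by the values given here, a weaker result is nonetheless expected, because the only measured example is a 4.4-fold higher number from compound 1 to compound 3 (0.64 log units; beyond the scatter). For compound 4 the expected step is a 3.3-fold higher number from compound 2 to compound 4 (0.52 log units; beyond the scatter). Compound 4 is estimated at 60 nM, between 20 nM and 200 nM.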

Compound 4, half-maximal effective concentration: 27 nM
Estimate against measurement, compound 4: 2.2-fold (0.35 log units) above, and the stated range covers the measured number.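

In this assay, adding the methyl gives a 1.5-fold higher number from compound 2 to compound 4 (0.18 log units; within the scatter), so on this core the change cannot be told apart from the scatter. On the core of compound 1, the same kind of change gives a clear step, and the two results do not agree: the same change on two cores in this assay, a 4.4-fold higher number (0.64 log units; beyond the scatter) from compound 1 to compound 3 and a 1.5-fold higher number (0.18 log units; within the scatter) from compound 2 to compound 4, 2.9-fold (0.46 log units) apart, beyond the scatter of two such steps

So the effect of this methyl does not carry over as a fixed amount from one core to another, but two pairs give no rule and do not show why, since the methyl also sits in a different place in each pair.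

On these data alone, it remains open whether a fluorine atom or a methoxy group ortho to an ethylcarbamoyl group would behave as the methyl of compound 4 does.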